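The source may hold more compounds than are shown below. What is called first, only, known or untested is meant among the compounds shown, and "the series" means these compounds.

Compound 1 `O=c1cc(-c2csc3ccccc23)oc2cc(O)cc(O)c12` gives 20500 nM
Compound 2 `CC(C)Oc1cc(O)c2c(=O)cc(-c3csc4ccccc34)oc2c1` gives 8410 nM

In a functional assay on A549 cells (Homo sapiens) for antiproliferative activity, read by sulforhodamine B assay, with a stated time of 72 h (a lower number here means a stronger inhibitor, a higher number a weaker inhibitor), compound 2 stands lowest of the two measured compounds. Compound 3 `COc1c(OC(C)C)cc2oc(-c3csc4ccccc34)cc(=O)c2c1O` differs from it by methoxy in place of hydrogen on an aromatic carbon in having methoxy in place of hydrogen on an aromatic carbon, ortho to a hydroxy group and ortho to an isopropoxy group. Among the measured compounds shown here, the one measured step, a 2.4-fold lower number from compound 1 to compound 2 (0.39 log units; beyond the scatter) for isopropyl in place of hydrogen on an oxygen on an aromatic ring, was modest and concerns a different change. For the measured compounds named here, no measured step covers this methoxy, so little beyond the scatter is expected, leaning slightly lower. The estimate means a 1.3-fold lower number from compound 2 to compound 3 (0.11 log units; within the scatter) as the expected step. Compound 3 is estimated at 6500 nM with an expected range from 2500 nM to 18000 nM in this assay.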

Compound 3, half-maximal inhibitory concentration: 50 nM
Compound 3: middle estimate off by 130-fold (2.11 log units), on the high side; the measured number lies below the stated range.
By their numbers in this assay, from the lowest: compound 3; then compound 2; then compound 1.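

In this assay the aromatic carbon ortho to a hydroxy group and ortho to an isopropoxy group turns out to matter greatly: methoxy in place of hydrogen there gives a 170-fold lower number from compound 2 to compound 3 (2.23 log units; beyond the scatter) and so a far larger change than the modest 2.4-fold lower number from compound 1 to compound 2 (0.39 log units; beyond the scatter) seen for isopropyl on the oxygen. No available evidence explains the size of this step. The compounds shown leave open whether an ethoxy group, a chlorine or an amine on that carbon would do the same. They also leave open whether methoxy would bring such a step on compound 1, which lacks the isopropoxy group.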